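Stereochemical Inversion of Compound 2 in HT-29 Cytotoxicity

The source may hold more compounds than are shown below. What is called first, only, known or untested is meant among the compounds shown, and "the series" means these compounds.

Measured compounds:
compound 1, `CC(=O)O[C@@H]1OC(=O)[C@](C)(C(C)=O)[C@@H]1C`: 5000 nM
compound 2, `CC(=O)O[C@@H]1OC(=O)[C@](Cc2ccccc2)(C(C)=O)[C@@H]1C`: 40000 nM
compound 3, `CC(=O)O[C@@H]1OC(=O)[C@](OC(C)=O)(C(C)=O)[C@@H]1C`: > 50000 nM

In a functional assay on HT-29 cells (Homo sapiens) for cytotoxicity, read by MTT assay (on this read-out lower numbers stand for stronger inhibition and higher numbers for weaker inhibition), compound 1 gives 5000 nM. Compound 2 gives 40000 nM in this assay, which is the highest of the two plain numbers. Compound 3 reaches only a limit of this assay, > 50000 nM, and no number. Among the measured steps, an 8.0-fold higher number from compound 1 to compound 2 (0.90 log units; beyond the scatter) and an at least 10-fold higher number from compound 1 to compound 3 (1.00 log units; beyond the scatter) both lie beyond the scatter, while an at least 1.2-fold higher number from compound 2 to compound 3 (0.09 log units; that floor lies within the scatter) has a floor that lies within it, with one value sitting at the limit of > 50000 nM in this assay, at which 1 of the 3 values shown sits.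

Compound 4, `CC(=O)O[C@@H]1OC(=O)[C@@](Cc2ccccc2)(C(C)=O)[C@@H]1C`, has not yet been measured in this assay. It differs from compound 2 as follows: the two compounds have the same atoms and bonds and differ only in configuration as drawn: 1 of 3 stereo elements differ; a stereocentre at a saturated ring carbon is drawn S in compound 2 and R in compound 4. Among the measured compounds shown here, none of the measured steps changes a stereocentre; each replaces one group with another, so no measured step bears directly on this inversion. For the measured compounds named here, with no comparable step to draw on, compound 4 is expected to give a number close to that of compound 2, with no change at the digits printed from compound 2 to compound 4 (within the scatter) expected to stay within the scatter. Compound 4 is accordingly estimated at 40000 nM, within a range from 15000 nM to 100000 nM, with a real chance that this assay reports only a limit.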

Compound 4, half-maximal inhibitory concentration: 39000 nM
For compound 4 the middle estimate is 1.0-fold (0.01 log units) above the measured one; the range from low to high includes it.
By their numbers in this assay, from the lowest: compound 1; then compounds 4 and 2 (each within the scatter of the next). At a limit, above all of these: compound 3.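

In this assay, inverting the stereocentre at the saturated ring carbon that carries the benzyl group gives a 1.0-fold lower number from compound 2 to compound 4 (0.01 log units; within the scatter), so the two drawn configurations at this carbon cannot be told apart on this read-out. The earlier steps shown here each replaced one group with another, whereas this pair isolates the arrangement of the groups at that carbon, with nothing else changed: the fact that compounds 2 and 4 differ only in the configuration as drawn. Set against an 8.0-fold higher number from compound 1 to compound 2 (0.90 log units; beyond the scatter), which lies beyond the scatter, this suggests that for these compounds the exchange of groups registers in the assay, while this single inversion, tested with the benzyl group in place, does not.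

The compounds shown leave open whether the same inversion would be as silent with the methyl group of compound 1, or with an amine, a carboxylic acid or a longer chain on that ring carbon. They also leave open what inverting either of the other two stereo elements would do, since both keep one configuration as drawn throughout.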